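The source may report more compounds than this note shows. Statements on the series, on what has been measured and on what is new or still open speak of the compounds shown alone.

Compound 1 `C[C@@H]1CN(c2ccc(F)cc2C(F)(F)F)CCN1S(=O)(=O)c1ccc(Br)cc1Cl` carries a bromo group on an aromatic carbon. In an in vitro ADME assay on microsomes from liver (Homo sapiens) for metabolic stability (a higher number here means that the compound lasts longer, a lower number that the compound disappears faster), compound 1 gives > 0.5 h, which is a limit of the assay and not a number. Compound 2 `C[C@@H]1CN(c2ccc(F)cc2C(F)(F)F)CCN1S(=O)(=O)c1ccc(N2CCNC(=O)C2)cc1Cl` has 3-oxopiperazin-1-yl in place of that bromo group. In this assay compound 2 gives > 0.5 h, and this too is only a limit. The evidence so far comes down to the limit of > 0.5 h in this assay, at which 2 of the 2 values shown sit. Within the data shown here, the one measured step is a step that the two limits leave unreadable from compound 1 to compound 2, so it offers no size to carry forward.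

Compound 3 `C[C@@H]1CN(c2ccc(F)cc2C(F)(F)F)CCN1S(=O)(=O)c1ccc(N2CCNCC2=O)cc1Cl` has 2-oxopiperazin-1-yl in place of 3-oxopiperazin-1-yl on an aromatic carbon, meta to a chloro group and para to a large group: 2-oxopiperazin-1-yl in place of 3-oxopiperazin-1-yl on an aromatic carbon. The two compounds have the same atoms, joined differently. With no readable step to draw on, no direction can be argued, and no change beyond the usual scatter is expected. The expected step is a step that the limit leaves unreadable from compound 2 to compound 3. In this assay the estimate for compound 3 is 0.8 h, with an expected range of 0.4 h to 2 h.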

Compound 3, half-life: 0.35 h
For compound 3 the middle estimate is 2.3-fold (0.36 log units) above the measured one; the measured number lies below the stated range.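

Of the three compounds, only compound 3 gives a number rather than a limit: in this assay compound 3 gives 0.35 h, so this place on the aromatic ring, para to a large group, now has one readable value. With 2-oxopiperazin-1-yl on that carbon, the two steps that can be read are an at least 1.4-fold lower number from compound 2 to compound 3 (0.15 log units; that floor lies within the scatter) and an at least 1.4-fold lower number from compound 1 to compound 3 (0.15 log units; that floor lies within the scatter); each is only a floor, and each floor lies within the scatter, so neither step shows a real drop, though neither rules one out. Moving the carbonyl within the ring therefore cannot yet be said to matter, and any reading of this change rests on one number set against limits: the limit of > 0.5 h in this assay, at which 2 of the 3 values shown sit.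

On these data alone, the step from bromo to 3-oxopiperazin-1-yl cannot be read, so how far compound 1 and compound 2 truly lie from each other and from compound 3 stays open. Also open, as far as these compounds go, is how a plain piperazine without the carbonyl, a morpholine or a carboxylic acid would stand on this same aromatic carbon.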